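Bile acid receptor series: amine to ether at the pyridine

The source may report more compounds than this note shows. Statements on the series, on what has been measured and on what is new or still open speak of the compounds shown alone.

Measured so far in a functional assay on HEK293 cells for agonist activity at Bile acid receptor (Homo sapiens), read by a luciferase reporter; on this read-out higher numbers stand for larger maximal responses and lower numbers for smaller maximal responses:
compound 1 `Cc1cc(C(F)(F)F)cc(OCc2c(-c3c(Cl)cccc3Cl)noc2C(C)C)n1` – "not active" (no number reported)
compound 2 `CC(C)c1onc(-c2c(Cl)cccc2Cl)c1COc1ccc(N(C)Cc2cccc(C(=O)O)c2)c(C(F)(F)F)n1` – 58%
compound 3 `CN(Cc1cccc(C(=O)O)c1)c1ccc(OCc2c(-c3c(Cl)cccc3Cl)noc2C2CC2)nc1C(F)(F)F` – 43%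

Going by the values given here, compound 3 stands lowest of the two numbers in this assay; its nearest neighbour is compound 2, and the single measured step is a number 15 percentage points lower from compound 2 to compound 3 (beyond the scatter), the only one-point change with a number on both sides. Compound 1 gave no number at all.

Compound 4 `CC(Oc1ccc(C(=O)O)cc1)c1ccc(OCc2c(-c3c(Cl)cccc3Cl)noc2C2CC2)nc1C(F)(F)F` differs from compound 3 by 1-(4-carboxyphenoxy)ethyl in place of (3-carboxybenzyl)(methyl)amino on an aromatic carbon.

Among the compounds with values here, no measured step touches this position: the step from compound 2 to compound 3 concerns the cyclopropyl in place of isopropyl on the other ring and says nothing about what replaces the (3-carboxybenzyl)(methyl)amino group. The series offers no guide here, so no step beyond the scatter is assumed in either direction, with the range kept wide. The expected step is a number 3 percentage points lower from compound 3 to compound 4 (within the scatter). Compound 4 is thus estimated at 40%, within 15% to 65%.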

Compound 4, largest response reached (reported as efficacy), in percent of the reference or control that the assay uses: 33%
The estimate for compound 4 lay 7 percentage points above the measured number, within the range that was stated.
By their numbers in this assay, from the lowest: compounds 4 and 3 (each within the scatter of the next); then compound 2.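

In this assay the exchange of (3-carboxybenzyl)(methyl)amino for 1-(4-carboxyphenoxy)ethyl, on the aromatic carbon ortho to the trifluoromethyl group, gives a number 10 percentage points lower from compound 3 to compound 4 (within the scatter), so this read-out does not separate the two groups. The nitrogen of the leaving group can thus give way to the oxygen of the entering group, with the carboxyl-bearing ring kept, without a step beyond the scatter. No measured information bears on this result.

The compounds shown leave open whether a tetrazole or a primary amide could stand in place of the carboxylic acid at this position, and whether a plain ethyl ether link would serve in place of the branched 1-(4-carboxyphenoxy)ethyl chain. They also leave open how 1-(4-carboxyphenoxy)ethyl behaves with isopropyl in place of cyclopropyl.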